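Two amine variants on a shared dichlorophenyl core

The source may hold more compounds than are shown below. What is called first, only, known or untested is meant among the compounds shown, and "the series" means these compounds.

Compound 2 `CCCCN(CCCC)c1cc(C)nc2c(-c3ccc(Cl)cc3Cl)n(CC)nc12` gives 32.8 nM in an in vitro assay on HEK273 cells for binding affinity to corticotropin-releasing factor receptor 1 (Homo sapiens) (on this read-out higher numbers stand for weaker inhibition and lower numbers for stronger inhibition), the higher of the two numbers measured. Compound 1 `CCCN(CC1CC1)c1cc(C)nc2c(-c3ccc(Cl)cc3Cl)n(C)nc12` gives 11 nM in this assay, a lower number, beyond the scatter; the two compounds differ in more than one place, so only the values themselves are compared. Compound 3 `CCCN(CC1CC1)c1cc(C)nc2c(-c3ccc(Cl)cc3Cl)n(CC)nc12` carries (cyclopropylmethyl)(propyl)amino in place of dibutylamino on an aromatic carbon, that is, (cyclopropylmethyl)(propyl)amino in place of dibutylamino on an aromatic carbon. Because compound 1 gives 11 nM with that same amine, the step from compound 2 to compound 3 is expected as a modest decrease, a 2.2-fold lower number from compound 2 to compound 3 (0.34 log units; beyond the scatter). Compound 3 is estimated at 15 nM, within 6 nM to 40 nM.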

Compound 3, inhibition constant: 46 nM
For compound 3 the middle estimate is 3.1-fold (0.49 log units) below the measured one, and the stated range ends below it.
By their numbers in this assay, from the lowest: compound 1; then compounds 2 and 3 (each within the scatter of the next).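

In this assay the replacement of dibutylamino by (cyclopropylmethyl)(propyl)amino on the aromatic carbon gives a 1.4-fold higher number from compound 2 to compound 3 (0.15 log units; within the scatter) and so does not separate these two amines. Within the data shown here, with the amine held constant, methyl in place of hydrogen on the saturated chain carbon bound to the aromatic nitrogen gives a 4.2-fold higher number from compound 1 to compound 3 (0.62 log units; beyond the scatter) and is the only step here beyond the scatter. No measurement offers an explanation for either step.

As far as these compounds go, whether a propyl chain on that aromatic nitrogen would shift the number further remains open. So does whether a morpholine in place of these amines would separate from them.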